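Removing the Hydroxymethyl Group: What to Expect for Compound 4

This account rests on a few compounds, and the source may have more. Where it says the series, first, only, none or still open, it means among the compounds named here.

Three compounds have been measured in a functional assay on SW707 cells (Homo sapiens) for cytotoxicity, read by sulforhodamine B assay, with a stated time of 72 h; on this read-out lower numbers stand for stronger inhibition and higher numbers for weaker inhibition:

Compound 1 `OCC#CCSc1cnc2ccccc2c1[Se]CC#CCBr` — 2.8 ug/mL
Compound 2 `CSc1c(SCC#CCO)cnc2ccccc12` — 69.3 ug/mL
Compound 3 `C#CC[Se]c1c(SCC#CCO)cnc2ccccc12` — 3.8 ug/mL

Compound 1 gives the lowest number of the three. Its nearest neighbour is compound 3: the step of a 1.4-fold higher number from compound 1 to compound 3 (0.13 log units; within the scatter) stays within the scatter, so the two cannot be ordered. The step of a 25-fold higher number from compound 1 to compound 2 (1.39 log units; beyond the scatter) is large, as is the step of an 18-fold lower number from compound 2 to compound 3 (1.26 log units; beyond the scatter); both separate compound 2 from the other two.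

Compound 4 `C#CCSc1cnc2ccccc2c1[Se]CC#CCBr` has not been measured. It differs from compound 1 in one place: hydrogen in place of hydroxymethyl on a triple-bonded carbon. Among the compounds with values here, the measured step that bears on this is the one from compound 1 to compound 3, where a hydrogen likewise replaced a group on a triple-bonded carbon, in that case bromomethyl, and the number barely moved. Within the data shown here, no measured step removes a hydroxymethyl group, so the comparison rests on that single analogy. On that basis the expected step of a 1.3-fold higher number from compound 1 to compound 4 (0.10 log units; within the scatter) is none beyond the scatter. The estimate for compound 4 in this assay is therefore 3.5 ug/mL, with a range from 1.5 ug/mL to 8 ug/mL.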

Compound 4, concentration for 50% inhibition: 2.2 ug/mL
Estimate against measurement, compound 4: 1.6-fold (0.20 log units) above; low and high end bracket the measured number.
By their numbers in this assay, from the lowest: compounds 4, 1 and 3 (each within the scatter of the next); then compound 2.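

In this assay, the step of a 1.3-fold lower number from compound 1 to compound 4 (0.10 log units; within the scatter) stays within the scatter, so in compound 1 the 4-hydroxybut-2-yn-1-yl chain can give way to propargyl, with the hydroxymethyl group and the hydrogen-bond donor and acceptor counted in it gone, without a readable change in the number. The earlier compounds had shown this kind of replacement only for bromomethyl, in the step of a 1.4-fold higher number from compound 1 to compound 3 (0.13 log units; within the scatter), so hydrogen has now replaced each of these groups on a triple-bonded carbon of compound 1, one at a time, with neither step beyond the scatter. No measurement at hand explains why the number holds after this change.

The compounds shown leave open whether the number would hold if hydroxymethyl and bromomethyl were both replaced by hydrogen in the same compound, since compound 3 retains hydroxymethyl and compound 4 retains bromomethyl. They also leave open what an amine, a carboxylic acid or a longer chain on this triple-bonded carbon would do to the number.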